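The source may report more compounds than this note shows. Statements on the series, on what has been measured and on what is new or still open speak of the compounds shown alone.

Measured in a functional assay on COR-L23 cells (Homo sapiens) for antiproliferative activity, read by CellTiter-Glo, with a stated time of 4 days; a higher number here means a weaker inhibitor, a lower number a stronger inhibitor:
- compound 1 `CCC(=O)N[C@@H](C)c1ccc(NC(=O)[C@H]2C[C@@H]2c2cccnc2)cc1`: 22 nM
- compound 2 `CC[C@H](NC(=O)c1ccccc1)c1ccc(NC(=O)[C@H]2C[C@@H]2c2cccnc2)cc1`: 137 nM
- compound 3 `C[C@H](NC(=O)C1CCOCC1)c1ccc(NC(=O)[C@H]2C[C@@H]2c2cccnc2)cc1`: 7 nM

Compound 3 has the lowest number of the three, with compound 1 and compound 2 both higher beyond the scatter. Compound 4 `C[C@H](NC(=O)c1ccccc1)c1ccc(NC(=O)[C@H]2C[C@@H]2c2cccnc2)cc1` has phenyl in place of oxan-4-yl on a carbonyl carbon.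

Among the measured compounds shown here, the one measured step at this place, a 3.1-fold lower number from compound 1 to compound 3 (0.50 log units; beyond the scatter), is modest. Compound 2 also carries phenyl there and reads 137 nM, but it differs from compound 4 by ethyl where compound 4 has methyl, so that value cannot be assigned to phenyl alone. A modest rise in this assay is therefore expected, similar in size to the measured step. The estimated step is a 2.9-fold higher number from compound 3 to compound 4 (0.46 log units; beyond the scatter). Compound 4 is estimated at 20 nM, with an expected range of 6 nM to 70 nM.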

Compound 4, half-maximal inhibitory concentration: 8 nM
Estimate against measurement, compound 4: 2.5-fold (0.40 log units) above, and the stated range covers the measured number.
By their numbers in this assay, from the lowest: compounds 3 and 4 (each within the scatter of the next); then compound 1; then compound 2.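

In this assay the carbonyl carbon takes phenyl as readily as oxan-4-yl (a 1.1-fold higher number from compound 3 to compound 4 (0.06 log units; within the scatter)), so the hydrogen-bond acceptor that leaves with oxan-4-yl is not required for a low number here. Ethyl at that place reads weaker than phenyl (a 2.8-fold lower number from compound 1 to compound 4 (0.44 log units; beyond the scatter)). With the benzamido group held constant, hydrogen in place of methyl on the saturated chain carbon gives by far the largest step (a 17-fold lower number from compound 2 to compound 4 (1.23 log units; beyond the scatter)). Nothing available explains these steps. Open, on these data alone, is whether a basic amine or a carboxylic acid on the carbonyl carbon would keep the number this low, and how a substituted phenyl would read there.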